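Compound 3 after losing a methoxy group

A few compounds are considered here, and "the series" means these few. Any claim that something is new, unique, unknown or untested is made for them only; others in the source may bear on it.

compound 1 `COc1cc(O)cc2c1OC[C@H](Cc1ccc(O)cc1)C2`: > 100000 nM (a limit)
compound 2 `COc1cc(O)c(C)c2c1CC[C@H](c1ccc(O)cc1)O2`: 89100 nM

Going by the values given here, only one true number exists so far. In a functional assay on B16-BL6 cells (Mus musculus) for cytotoxicity, read by MTT assay, with a stated time of 72 h (a lower number here means a stronger inhibitor, a higher number a weaker inhibitor), compound 2 gives 89100 nM, and that is the sole measured figure in the set. The value of compound 1, > 100000 nM, is a limit of the assay and not a number. The two compounds also differ in more than one place, so no single structural step can be read from them.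

The next compound is compound 3 `Cc1c(O)ccc2c1O[C@@H](c1ccc(O)cc1)CC2`. It differs from compound 2 by hydrogen in place of methoxy on an aromatic carbon, meta to a hydroxy group and para to a methyl group.

Among the compounds with values here, no measured step shows what this change does in this assay, so compound 2 at 89100 nM is the only anchor. The expected step of a 1.3-fold lower number from compound 2 to compound 3 (0.10 log units; within the scatter) stays within the usual scatter, with no firm direction. Compound 3 may also land at the limit of > 100000 nM in this assay, at which 1 of the 2 values shown sits. For compound 3 the expected value is 70000 nM, with an estimated range from 25000 nM to 100000 nM.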

Compound 3, half-maximal inhibitory concentration: 98900 nM
The estimate for compound 3 lay 1.4-fold (0.15 log units) below the measured number; measured number inside the range.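

Going by these compounds alone, replacing the methoxy group with hydrogen, on an aromatic carbon meta to a hydroxy group and para to a methyl group, gives the first step that can be read in this assay: a 1.1-fold higher number from compound 2 to compound 3 (0.05 log units; within the scatter). The two compounds therefore cannot be told apart in these cells, and the methoxy group on this carbon is not needed for the weak cytotoxicity they share. The comparison has limited reach, however, since both numbers lie close to the top of what this read-out reports, and any further weakening from a change at this position could hardly be seen: the limit of > 100000 nM in this assay, at which 1 of the 3 values shown sits.

What the compounds shown leave open is whether any group on this carbon can make the number clearly lower, for example an amine, a carboxylic acid or a longer alkoxy chain in place of the hydrogen. From the compounds shown here alone, a neutral result between two weak compounds says little about how a more active compound would respond to the same change, and the roles of the neighbouring hydroxy and methyl groups also remain untested here.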